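The compounds below may be only part of what the source reports. "The series", "measured", "known", "first", "only" and "open" are said of these compounds alone.

The set comprises three measured compounds and one still to be measured. Compound 1 `Cn1c(NC(=O)c2cccnc2)cc2ccccc21`, compound 2 `O=C(Cn1ccccc1=O)Nc1cc2ccccc2[nH]1` and compound 3 `COC(=O)c1ccc2ccn(C(=O)c3ccccc3)c2c1` have each been run in an ADME assay for permeability, using PAMPA, at pH 7.4; a lower number here means that the compound crosses the layer more slowly, a higher number that the compound crosses the layer faster. In this assay compound 1 gives 4.9 10^-6 cm/s, compound 2 gives 0.1 10^-6 cm/s and compound 3 gives 0.5 10^-6 cm/s. Compound 2 thus stands lowest of the three: compound 3 sits a step above it that lies beyond the scatter, and compound 1 sits further above still, again beyond the scatter.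

Compound 4 `Cn1c(NC(=O)Cn2ccccc2=O)cc2ccccc21` has not yet been measured. It differs from compound 2 in one place: methyl in place of hydrogen on an aromatic nitrogen. The change sits on an aromatic nitrogen of a five-membered aromatic ring with one nitrogen, part of a fused system of two rings.

Among the compounds with values here, no pair of measured compounds differs in just this way, so the size of the step has to be guessed. The guess leans on compound 1, which carries a methyl on the same kind of aromatic nitrogen and gives 4.9 10^-6 cm/s in this assay, far above compound 2. An upward step from compound 2 to compound 4 is therefore expected, of a 15-fold higher number from compound 2 to compound 4 (1.18 log units; beyond the scatter), and it is expected to exceed the scatter. Compound 4 is estimated at 1.5 10^-6 cm/s, with a range from 0.4 10^-6 cm/s to 5 10^-6 cm/s.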

Compound 4, apparent permeability in the ADME assay: 3.3 10^-6 cm/s
The estimate for compound 4 lay 2.2-fold (0.34 log units) below the measured number; low and high end bracket the measured number.
By their numbers in the ADME assay, from the lowest: compound 2; then compound 3; then compounds 4 and 1 (each within the scatter of the next).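

Within the data shown here, in the ADME assay, the single exchange of methyl for hydrogen on an aromatic nitrogen gives a 33-fold higher number from compound 2 to compound 4 (1.52 log units; beyond the scatter), which shows within one matched pair that this position alone can carry a large step; the earlier compounds differed in more than one place and could not show this. In a physicochemical assay for lipophilicity (a lower number here means a more polar compound, a higher number a more lipophilic compound), compound 2 gives 0.4 and compound 4 gives 1.1. The same change thus raises both read-outs, and the gain in permeability may be due in part to the higher lipophilicity, although a single pair cannot separate this from the loss of the hydrogen on that nitrogen: the measured partition coefficient of compound 2, 0.4, and of compound 4, 1.1, a number 0.70 log units higher (beyond the scatter)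

From the compounds shown here alone, this is one pair, so it remains open whether an ethyl group, a longer chain or a chain ending in an amine on the same nitrogen would move the numbers further, hold them or reverse the step. It is also open whether the step has the same size with another group on the amide, since compound 1 has no partner among the compounds shown that differs from it only by this methyl.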